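Swapping the Amide Aryl Group in a Dopamine Receptor Series

This account rests on a few compounds, and the source may have more. Where it says the series, first, only, none or still open, it means among the compounds named here.

Compound 1 `O=C(CN1CCC(c2cccc[n+]2[O-])CC1)Nc1cccc(Cl)c1` was tested in a functional assay on HEK293 cells for agonist activity at D(4) dopamine receptor (Homo sapiens), read by FLIPR (a higher number here means a larger maximal response, a lower number a smaller maximal response), where compound 1 gives 76%. Going by the values given here, that is the highest of the three numbers measured so far. Among the compounds with values here, compound 2 `N#Cc1cccc(C(=O)NCN2CCC(c3cccc[n+]3[O-])CC2)c1` gives 69%, a value within the usual scatter of the one for compound 1. Compound 3 `Cc1cccc(NC(=O)CN2CCC(c3ccccc3C)CC2)c1` gives 43%, which lies beyond the scatter below compound 1. Compound 4 `Cc1cccc(C)c1NC(=O)CN1CCC(c2cccc[n+]2[O-])CC1` has not yet been measured. It differs from compound 1 in one place: 2,6-dimethylphenyl in place of 3-chlorophenyl on an amide-type nitrogen. Within the data shown here, no measured pair shows this exact change, so its effect is not known from the data. A moderate drop in maximal response is expected, the step being estimated as a number 16 percentage points lower from compound 1 to compound 4 (beyond the scatter). Compound 4 is expected to give 60%, within a range from 40% to 80%.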

Compound 4, largest response reached (reported as efficacy), in percent of the reference or control that the assay uses: 68%
Estimate against measurement, compound 4: 8 percentage points below, within the range that was stated.
By their numbers in this assay, from the lowest: compound 3; then compounds 4, 2 and 1 (each within the scatter of the next).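

In this assay, going by these compounds alone, the first direct comparison at this position puts 2,6-dimethylphenyl in place of 3-chlorophenyl on the amide-type nitrogen, and the step is a number 8 percentage points lower from compound 1 to compound 4 (within the scatter) in maximal response. The two aryl groups therefore cannot be told apart here, even though they carry different substituents, so this change leaves the response within normal measurement variation. No measured property is available to explain this result.

As far as these compounds go, whether a non-aromatic cyclohexyl group would keep the response at this position remains open. So does the effect of a phenyl group carrying a carboxylic acid or an amine.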